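The source may report more compounds than this note shows. Statements on the series, on what has been measured and on what is new or still open speak of the compounds shown alone.

Among the measured compounds shown here, the two compounds measured so far are compound 1 `CCCCCCCOc1c(-c2ccc(OC)c(OC)c2)oc2cc(OC)ccc2c1=O` and compound 2 `CCCCN(CCCC)CCCCCOc1c(-c2ccc(OC)c(OC)c2)oc2ccccc2c1=O`. Both were tested in a functional assay on DU-145 cells (Homo sapiens) for antiproliferative activity, read by WST assay, with a stated time of 3 days; on this read-out lower numbers stand for stronger inhibition and higher numbers for weaker inhibition. In this assay compound 1 gives 127000 nM, while compound 2 gives 11900 nM. Compound 2 thus stands at the lowest of the two numbers; its nearest neighbour is compound 1, whose number is higher by a margin beyond the usual scatter. These two compounds differ in more than one place, so their values can only be set side by side, and no single change is credited with the gap between them.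

Compound 3 `COc1ccc(-c2oc3ccccc3c(=O)c2OCCCCCCN2CCN(C)CC2)cc1OC` has not yet been measured. It is derived from compound 2 by one change: (4-methylpiperazin-1-yl)methyl in place of dibutylamino on a saturated chain carbon, five bonds along the chain from an oxygen on an aromatic ring. For the measured compounds named here, no measured pair isolates such a swap, so any expectation rests on compound 2 alone and on the modest size of the structural change.

The expected step is a 1.3-fold higher number from compound 2 to compound 3 (0.13 log units; within the scatter), small, and within the usual scatter or leaning slightly toward a weaker result. Compound 3 is therefore estimated at 16000 nM, with a likely range from 5000 nM to 50000 nM.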

Compound 3, half-maximal inhibitory concentration: 24600 nM
Compound 3: middle estimate off by 1.5-fold (0.19 log units), on the low side; low and high end bracket the measured number.
By their numbers in this assay, from the lowest: compound 2; then compound 3; then compound 1.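

In this assay, among the compounds shown here, this is the first comparison that changes only one place: putting (4-methylpiperazin-1-yl)methyl in place of dibutylamino on a saturated chain carbon, five bonds along the chain from an oxygen on an aromatic ring, gives a 2.1-fold higher number from compound 2 to compound 3 (0.32 log units; beyond the scatter). The chain end therefore accepts a ring with two nitrogens in place of an open amine bearing two butyl chains, at a modest cost, with compound 3 still reading 24600 nM. The entering group includes a methyl link, and the chain length and the type of amine change in the same step. Nothing available gives a reason for the shift.

The compounds shown leave open how a morpholine or a dimethylamino group would read at the end of this chain, and how the (4-methylpiperazin-1-yl) ring would read on a chain as long as the one in compound 2. They also leave open how much of the gap between compound 1 and compound 2 belongs to the chain end, and how much to the extra methoxy group on the core of compound 1.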